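Dropping One Chloro From the Pendant Ring

A few compounds are considered here, and "the series" means these few. Any claim that something is new, unique, unknown or untested is made for them only; others in the source may bear on it.

Measured so far:
compound 1 `COc1cc(/C=C/C(=O)C2=C(/C=C/c3ccc(O)c(OC)c3)NC(=O)NC2c2ccc(N(C)C)cc2)ccc1O` gives 28.2%
compound 2 `COc1cc(/C=C/C(=O)C2=C(/C=C/c3ccc(O)c(OC)c3)NC(=O)NC2c2c(Cl)cccc2Cl)ccc1O` gives 11.2%

In a functional assay, with a stated time of 20 min, tested at 2 uM (a higher number here means a stronger effect of the compound at the concentration tested, a lower number a weaker effect), compound 2 holds the lower of the two numbers. Going by the values given here, the only measured step, a number 17 percentage points lower from compound 1 to compound 2 (beyond the scatter), swapped the whole pendant group at once. Compound 3 `COc1cc(/C=C/C(=O)C2=C(/C=C/c3ccc(O)c(OC)c3)NC(=O)NC2c2ccccc2Cl)ccc1O` is made from compound 2 by hydrogen in place of chloro on an aromatic carbon. Among the compounds with values here, no measured step removes a single chloro, so that one step only sets a rough scale of what an aryl change can do. Compound 3 is therefore expected to move by a number 4.8 percentage points higher from compound 2 to compound 3 (within the scatter), within the scatter. The estimate for compound 3 is 16%, ranging from 5% to 30%.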

Compound 3, a percentage reported as activity, at one concentration (the size of the read-out at that concentration, not a potency): 16.6%
Compound 3: the middle estimate sits 0.6 percentage points below what was measured; the range from low to high includes it.
By their numbers in this assay, from the lowest: compounds 2 and 3 (each within the scatter of the next); then compound 1.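

In this assay, taking one chloro off the pendant ring gives a step that stays within the scatter (a number 5.4 percentage points higher from compound 2 to compound 3 (within the scatter)), so 2,6-dichlorophenyl and 2-chlorophenyl cannot be told apart at this position. The gap to the 4-(dimethylamino)phenyl compound remains beyond the scatter with only one chloro present (a number 11.6 percentage points lower from compound 1 to compound 3 (beyond the scatter)). Nothing available explains either step.

Going by these compounds, it remains open what an unsubstituted phenyl ring would give, or a methoxy group in place of the remaining chloro. Also open, on these data alone, is whether the higher number of compound 1 depends on its dimethylamino group or merely on the absence of chloro.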